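A dichlorobenzyl swap without a measured starting point

The source may report more compounds than this note shows. Statements on the series, on what has been measured and on what is new or still open speak of the compounds shown alone.

Measured in a functional assay on G-361 cells (Homo sapiens) for antiproliferative activity, with a stated time of 72 h; a higher number here means a weaker inhibitor, a lower number a stronger inhibitor:
compound 1 `OC[C@H]1O[C@@H](n2cnc3c(NCc4ccc(F)cc4)ncnc32)[C@H](O)[C@@H]1O`: > 166000 nM (a limit)
compound 2 `OC[C@H]1O[C@@H](n2cnc3c(NCc4ccc(Cl)cc4)ncnc32)[C@H](O)[C@@H]1O`: > 166000 nM (a limit)
compound 3 `Cc1ccc(CNc2ncnc3c2ncn3[C@@H]2O[C@H](CO)[C@@H](O)[C@H]2O)cc1`: "not determined" (no result reported)

Compound 3 has no number of its own in this assay, so the step starts from no known value. The only other results are two limits at one shared ceiling, (the limit of > 166000 nM in this assay, at which 2 of the 3 values shown sit).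

Compound 4 `OC[C@H]1O[C@@H](n2cnc3c(NCc4ccc(Cl)c(Cl)c4)ncnc32)[C@H](O)[C@@H]1O` differs from compound 3 by 3,4-dichlorophenyl in place of 4-methylphenyl on a saturated chain carbon bound to a nitrogen on an aromatic ring, a change from 4-methylbenzyl to 3,4-dichlorobenzyl.

For the measured compounds named here, the one measured step that bears on this is a step that the two limits leave unreadable from compound 1 to compound 2, with chloro in place of fluoro. Its size cannot be read, so no size or direction can be expected for the step from compound 3. Compound 2, which also carries chloro, gives > 166000 nM, and this is a limit. Compound 4 is therefore expected to lie near that ceiling, and the assay may well report only a limit.

For compound 4 the expected value is about 150000 nM, with an estimated range from 60000 nM to 166000 nM.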

Compound 4, half-maximal inhibitory concentration: 145000 nM
For compound 4 the middle estimate is 1.0-fold (0.01 log units) above the measured one, and the stated range covers the measured number.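

In this assay compound 4 gives 145000 nM, the only number among the compounds shown that is not a limit. That number makes two steps readable, a second chloro as an at least 1.1-fold lower number from compound 2 to compound 4 (0.05 log units; that floor lies within the scatter) and 3,4-dichlorophenyl in place of 4-fluorophenyl as an at least 1.1-fold lower number from compound 1 to compound 4 (0.05 log units; that floor lies within the scatter), but both floors lie within the scatter, so neither shows by itself a change beyond it. At this place, on a saturated chain carbon bound to a nitrogen on an aromatic ring, 3,4-dichlorophenyl thus gives a readable value that still stays close to the series' shared ceiling: the limit of > 166000 nM in this assay, at which 2 of the 4 values shown sit.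

The steps from compound 3 to compound 4 and from compound 1 to compound 2 cannot be read. Also open, from the compounds shown here alone, is how a trifluoromethyl group or a carboxylic acid on the phenyl ring, or a longer chain in place of the benzyl group, would read in this assay.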